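Removing the methoxy from the aryl ketone of compound 3

The source may report more compounds than this note shows. Statements on the series, on what has been measured and on what is new or still open speak of the compounds shown alone.

Three aryl ketones sharing one core have been measured. Compound 1 `O=C(CSc1nc2ccccc2[nH]1)c1ccc(Br)cc1` gives 43000 nM in a functional assay on HT-29 cells (Homo sapiens) for inhibition, read by WST assay, with a stated time of 48 h; on this read-out higher numbers stand for weaker inhibition and lower numbers for stronger inhibition. Compound 2 `COc1ccccc1C(=O)CSc1nc2ccccc2[nH]1` gives 36100 nM in this assay. Compound 3 `COc1ccc(C(=O)CSc2nc3ccccc3[nH]2)cc1` gives 25200 nM in this assay, the lowest of the three numbers, though compound 2 and compound 1 both lie within the scatter of it. Among the compounds with values here, the one single-point comparison available, a 1.7-fold lower number from compound 1 to compound 3 (0.23 log units; within the scatter), is itself within the scatter.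

Compound 4 `O=C(CSc1nc2ccccc2[nH]1)c1ccccc1` is compound 3 with the methoxy removed: hydrogen in place of methoxy on an aromatic carbon. Within the data shown here, no measured step removes this group; the only bearing comparison is a 1.7-fold lower number from compound 1 to compound 3 (0.23 log units; within the scatter), where exchanging one substituent at this position for another moved the number by less than the scatter. The expectation for compound 4 is therefore no step beyond the scatter, with the estimated change a 1.3-fold higher number from compound 3 to compound 4 (0.10 log units; within the scatter) leaning slightly toward a higher number because compound 3 already gives 25200 nM and nothing in the series shows the bare ring doing better. Compound 4 is estimated at 32000 nM in this assay, in the range 13000 nM to 80000 nM.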

Compound 4, half-maximal inhibitory concentration: 38500 nM
Compound 4: the middle estimate sits 1.2-fold (0.08 log units) below what was measured, and the stated range covers the measured number.
By their numbers in this assay, from the lowest: compounds 3, 2, 4 and 1 (each within the scatter of the next).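

In this assay, removing the methoxy gives a 1.5-fold higher number from compound 3 to compound 4 (0.18 log units; within the scatter), the same exchange starting from the other methoxy ketone gives a 1.1-fold higher number from compound 2 to compound 4 (0.03 log units; within the scatter), and removing the bromo gives a 1.1-fold lower number from compound 1 to compound 4 (0.05 log units; within the scatter). The bare ring thus supplies the missing reference point: all three steps lie within the scatter, so neither methoxy nor bromo is shown to shift the number relative to hydrogen on this aromatic ring. No supporting data on the compounds accompany these values, so the small steps cannot be interpreted further.

Going by these compounds, it remains open whether a different substituent on this ring, such as an amine, a carboxylic acid or a nitrile, would give a step beyond the scatter. On these data alone, it is equally open whether a change to the shared core would move the number more than these ring substituents do.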